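Notes on the step from compound 3 to compound 4

The compounds below may be only part of what the source reports. "The series", "measured", "known", "first", "only" and "open" are said of these compounds alone.

The set shares one core, seen in compound 1 `CNC(=O)c1cc(Oc2ccc(/C=C/C(=O)c3ccc([N+](=O)[O-])cc3)cc2)ccn1`, compound 2 `CNC(=O)c1cc(Oc2ccc(C(=O)/C=C/c3cccc([N+](=O)[O-])c3)cc2)ccn1` and compound 3 `CNC(=O)c1cc(Oc2ccc(C(=O)/C=C/c3ccc(C#N)cc3)cc2)ccn1`. In a functional assay on A549 cells (Homo sapiens) for cytotoxicity, read by MTT assay, with a stated time of 72 h (a lower number here means a stronger inhibitor, a higher number a weaker inhibitor), compound 1 gives "not determined" (no result reported), and compound 2 likewise gives "not determined" (no result reported); neither carries a number. For the measured compounds named here, compound 3 is therefore the only member with a value: in this assay compound 3 gives 26400 nM, a weak inhibition and the single reference point of the series. Going by the values given here, no step between two measured compounds exists, so no measured change of the assay number is available to calibrate the next move.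

Compound 4 `CNC(=O)c1cc(Oc2ccc(C(=O)/C=C/c3cccc(Br)c3)cc2)ccn1` is the compound still to be measured. It differs from compound 3 in one place: 3-bromophenyl in place of 4-cyanophenyl on a double-bonded chain carbon bound to a double-bonded chain carbon. Among the compounds with values here, with only one value in hand and no measured step, the expectation for this assay can rest on nothing but the single number of compound 3 and the limited size of the change. The expected step is a 1.5-fold lower number from compound 3 to compound 4 (0.17 log units; within the scatter), a modest move toward stronger inhibition that stays close to the scatter. Compound 4 is expected to give 18000 nM in this assay, within an estimated range from 6000 nM to 55000 nM.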

Compound 4, half-maximal inhibitory concentration: 9940 nM
The estimate for compound 4 lay 1.8-fold (0.26 log units) above the measured number, within the range that was stated.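

With 3-bromophenyl in place of 4-cyanophenyl on a double-bonded chain carbon bound to a double-bonded chain carbon, this assay gives the series its first measured step, a 2.7-fold lower number from compound 3 to compound 4 (0.42 log units; beyond the scatter), a modest move toward stronger inhibition that lies beyond the usual scatter. This shows that the number responds to a change of the aryl group at this place, and that a nitrile with its triple bond and hydrogen-bond acceptor is not required for activity at this level. No measurement on hand accounts for the shift, so the step stands as an observation only.

For the compounds shown here, the step changes the substituent and its place on the ring together, so 3-cyanophenyl and 4-bromophenyl would be needed to separate the two, while compound 1 and compound 2, with no number in this assay, give no steps that can be read. Also open, on these data alone, is how the number would respond to an amine or a carboxylic acid on this ring, and whether any group here can move it further than this single step has.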